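The compounds below may be only part of what the source reports. "The series", "measured", "known", "first", "only" and "open" are said of these compounds alone.

Of the compounds shown here, three built on one shared core have been tested in an assay on CHO cells for displacement of a labelled ligand from adenosine receptor A1 (Homo sapiens), read by scintillation counting, with a stated time of 3 h; a higher number here means a weaker inhibitor, a lower number a stronger inhibitor. Compound 1 `Cc1ccc(C(=O)Nc2nc(Cl)c3cn(C)nc3n2)cc1` gives > 100000 nM, which is a limit of the assay and not a number. Compound 2 `Cn1cc2c(Cl)nc(NC(=O)c3ccc(C(F)(F)F)cc3)nc2n1` gives > 100000 nM, again a limit and not a number. Within the data shown here, compound 3 `Cc1ccc(C(=O)Nc2nc(Cl)c3cn(C(C)C)nc3n2)cc1` gives 4100 nM, the only number among the three. Compound 3 differs from compound 1 by isopropyl in place of methyl on an aromatic nitrogen, and the step is an at least 24-fold lower number from compound 1 to compound 3 (1.38 log units; beyond the scatter). Compound 2 differs from compound 1 by trifluoromethyl in place of methyl on an aromatic carbon, and here the step is a step that the two limits leave unreadable from compound 1 to compound 2 because both values sit at the limit of > 100000 nM in this assay, at which 2 of the 3 values shown sit. Compound 4 `CC(C)n1cc2c(Cl)nc(NC(=O)c3ccc(C(F)(F)F)cc3)nc2n1` has not yet been measured in this assay. It differs from compound 3 by trifluoromethyl in place of methyl on an aromatic carbon, the same change that separates compound 1 from compound 2, applied to the core of compound 3 rather than the core of compound 1. Among the measured compounds shown here, the one measured instance of this change leaves no readable step, so no direction can be drawn from it. Compound 4 is therefore expected to stay close to compound 3, with an expected step of a 1.5-fold higher number from compound 3 to compound 4 (0.17 log units; within the scatter) in this assay. Compound 4 is estimated at 6000 nM, with an expected range from 1500 nM to 30000 nM.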

Compound 4, inhibition constant: 13800 nM
The estimate for compound 4 lay 2.3-fold (0.36 log units) below the measured number; measured number inside the range.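

In this assay, trifluoromethyl in place of methyl on an aromatic carbon gives a 3.4-fold higher number from compound 3 to compound 4 (0.53 log units; beyond the scatter), which is the only readable size for this change, so it cannot be said whether that size carries over from one core to the other. The same change on the core of compound 1 cannot be read, as compound 1 and compound 2 both sit at a limit of the assay: the limit of > 100000 nM in this assay, at which 2 of the 4 values shown sit. Isopropyl in place of methyl on an aromatic nitrogen gives an at least 7.2-fold lower number from compound 2 to compound 4 (0.86 log units; beyond the scatter), which points the same way as the earlier step on the core of compound 1, although this agreement in direction rests on only two pairs and does not fix the size of either step: the same change on two cores in this assay, an at least 24-fold lower number (1.38 log units; beyond the scatter) from compound 1 to compound 3 and an at least 7.2-fold lower number (0.86 log units; beyond the scatter) from compound 2 to compound 4; the limit leaves it open whether they differ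

The compounds shown leave open how a longer chain would read on that aromatic nitrogen. They also leave open how a nitrile or an amine would read on the aromatic carbon that carries methyl in compound 3.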